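Weak Antiproliferative Spiro Compounds and a Dinitrophenyl Swap

The source may report more compounds than this note shows. Statements on the series, on what has been measured and on what is new or still open speak of the compounds shown alone.

Three compounds built on one shared core were tested in a functional assay on MCF7 cells (Homo sapiens) for antiproliferative activity, read by MTT assay, with a stated time of 48 h; on this read-out higher numbers stand for weaker inhibition and lower numbers for stronger inhibition. Compound 1 `Cc1ccccc1-n1nncc1CN1C(=O)C2(C(C#N)=C(N)Oc3c2c2nc4ccccc4nc2c2ccccc32)c2ccccc21` reaches only a limit of the assay, > 50000 nM. Compound 2 `N#CC1=C(N)Oc2c(c3nc4ccccc4nc3c3ccccc23)C12C(=O)N(Cc1cnnn1-c1ccccc1Cl)c1ccccc12` also stops at a limit, > 50000 nM. For the measured compounds named here, the single step between measured neighbours, a step that the two limits leave unreadable from compound 1 to compound 2, is therefore blank. Compound 3 `N#CC1=C(N)Oc2c(N)cc3nc4ccccc4nc3c2C12C(=O)N(Cc1cnnn1-c1cccc(C(F)(F)F)c1)c1ccccc12` stands alone in giving a number: in this assay compound 3 gives 31600 nM, a weak result, yet one that lies apart from the limit of > 50000 nM in this assay, at which 2 of the 3 values shown sit.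

Compound 4 `N#CC1=C(N)Oc2c(N)cc3nc4ccccc4nc3c2C12C(=O)N(Cc1cnnn1-c1ccc([N+](=O)[O-])cc1[N+](=O)[O-])c1ccccc12` differs from compound 3 in one place: 2,4-dinitrophenyl in place of 3-(trifluoromethyl)phenyl on an aromatic nitrogen. Going by the values given here, no measured step concerns this position, and the one computed step is unreadable, so the data give no direction for the change. The step of a 1.1-fold higher number from compound 3 to compound 4 (0.04 log units; within the scatter) is expected to stay within the usual scatter, with a real chance that the assay returns only a limit. Compound 4 is expected to give about 35000 nM, with a range from 10000 nM to 120000 nM.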

Compound 4, half-maximal inhibitory concentration: 20900 nM
Compound 4: middle estimate off by 1.7-fold (0.22 log units), on the high side; low and high end bracket the measured number.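

On the aromatic nitrogen of the five-membered ring, 2,4-dinitrophenyl in place of 3-(trifluoromethyl)phenyl gives a 1.5-fold lower number from compound 3 to compound 4 (0.18 log units; within the scatter) in this assay. The two groups therefore cannot be told apart on this read-out, even though the entering group carries 4 hydrogen-bond acceptors and the leaving group 0. With the same core and a second group at this position, compound 4 also gives a number rather than a limit, which is not a given in this set: the limit of > 50000 nM in this assay, at which 2 of the 4 values shown sit.

The compounds shown leave open whether a single nitro group, as in 4-nitrophenyl, would give a similar number to the two nitro groups of compound 4. They also leave open whether a carboxylic acid on the phenyl ring, or an aminoethyl chain in place of the ring, would move the number beyond the usual scatter.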